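Aromatic nitrogen substituent swaps in one inactive series

The source may hold more compounds than are shown below. What is called first, only, known or untested is meant among the compounds shown, and "the series" means these compounds.

Measured compounds, all read in an ADME assay on HUVEC cells (Homo sapiens) for antiproliferative activity, read by MTT assay, with a stated time of 48 h; on this read-out lower numbers stand for stronger inhibition and higher numbers for weaker inhibition:
compound 1 `N#CC1=C(N)Oc2c(N)cc3nc4ccccc4nc3c2C12C(=O)N(Cc1cnnn1-c1cccc(C(F)(F)F)c1)c1ccccc12` gives > 50000 nM
compound 2 `CCc1cccc(CC)c1-n1nncc1CN1C(=O)C2(C(C#N)=C(N)Oc3c(N)cc4nc5ccccc5nc4c32)c2ccccc21` gives > 50000 nM
compound 3 `COc1ccc(OC)c(-n2nncc2CN2C(=O)C3(C(C#N)=C(N)Oc4c(N)cc5nc6ccccc6nc5c43)c3ccccc32)c1` gives > 50000 nM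

Every one of these values is a limit of this assay and not a number. Compound 3 therefore stands at that limit, and the two further values shown are limits as well, so no ordering among the three can be read. The three single-point changes between them are accordingly unreadable: a step that the two limits leave unreadable from compound 1 to compound 2, a step that the two limits leave unreadable from compound 1 to compound 3 and a step that the two limits leave unreadable from compound 2 to compound 3. Among the measured compounds shown here, the only evidence on the measured steps is the limit of > 50000 nM in this assay, at which 3 of the 3 values shown sit.

The next change is 2,4-dinitrophenyl in place of 2,5-dimethoxyphenyl on an aromatic nitrogen, giving compound 4 `N#CC1=C(N)Oc2c(N)cc3nc4ccccc4nc3c2C12C(=O)N(Cc1cnnn1-c1ccc([N+](=O)[O-])cc1[N+](=O)[O-])c1ccccc12`. The three measured compounds, with three different groups on the same aromatic nitrogen, all sit at the limit, and nothing in the data separates one group from another at this position. The 2,4-dinitrophenyl group is a fourth variation at the same place, so the expectation for compound 4 is again a limit rather than a number, with an expected step of a number no higher from compound 3 to compound 4 (the limit leaves the size open) relative to compound 3. Compound 4 is estimated at 50000 nM, in the range 20000 nM to 100000 nM, most probably reported only as a limit.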

Compound 4, half-maximal inhibitory concentration: > 50000 nM
Compound 4 was reported as a limit; the forecaster's own chance of this, stated with the estimate: 85%; the middle value sits exactly at the limit.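

In this assay compound 4 gives > 50000 nM and this is a limit, not a number. Among the compounds shown here, its steps from compound 1, compound 2 and compound 3 therefore cannot be read, and no new step follows from this result: the limit of > 50000 nM in this assay, at which 4 of the 4 values shown sit.

Still open, going by these compounds, is whether in this assay any group on this aromatic nitrogen gives a number rather than a limit.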